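The compounds below may be only part of what the source reports. "The series", "measured", "known", "first", "only" and "open" are said of these compounds alone.

Within the data shown here, compound 2 `CN1CCC(N2CC(COCc3cc(C(F)(F)F)cc(C(F)(F)F)c3)(c3ccc(F)cc3)NC2=O)CC1` stands lowest of the two numbers measured so far in an assay on CHO cells for displacement of a labelled ligand from Substance-P receptor (Homo sapiens); on this read-out higher numbers stand for weaker inhibition and lower numbers for stronger inhibition: in this assay compound 2 gives 0.4 nM. Among the measured compounds shown here, its only neighbour is compound 1 `O=C1NC(COCc2cc(C(F)(F)F)cc(C(F)(F)F)c2)(c2ccc(F)cc2)CN1C1CCNCC1`, which carries a hydrogen where compound 2 carries a methyl on the amine nitrogen in the ring; in this assay compound 1 gives 0.9 nM, and the change is a 2.3-fold lower number from compound 1 to compound 2 (0.35 log units; beyond the scatter).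

Compound 3 `O=C1NCC(COCc2cc(C(F)(F)F)cc(C(F)(F)F)c2)(c2ccc(F)cc2)N1` departs from compound 2 by a larger change: hydrogen in place of 1-methylpiperidin-4-yl on an amide-type nitrogen in a ring. For the measured compounds named here, the one measured step only swapped a small substituent on that same ring while the ring itself stayed; here the whole ring leaves, and no measured compound shows the shared core without it. That step therefore gives no direct scale for the present change, and the expectation rests on the observation that both measured compounds keep the ring and both reach low numbers. Removing it entirely is expected to weaken inhibition rather than strengthen it. The expected step is a 13-fold higher number from compound 2 to compound 3 (1.10 log units; beyond the scatter). Compound 3 is estimated at 5 nM, with a range from 1 nM to 30 nM.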

Compound 3, inhibition constant: 4.5 nM
The estimate for compound 3 lay 1.1-fold (0.05 log units) above the measured number; low and high end bracket the measured number.
By their numbers in this assay, from the lowest: compound 2; then compound 1; then compound 3.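

Putting hydrogen on the amide-type nitrogen in place of the ring-bearing group weakens inhibition in this assay from both earlier compounds: removing 1-methylpiperidin-4-yl gives an 11-fold higher number from compound 2 to compound 3 (1.05 log units; beyond the scatter), and removing piperidin-4-yl gives a 5.0-fold higher number from compound 1 to compound 3 (0.70 log units; beyond the scatter). The earlier step only showed that a methyl on the ring's amine nitrogen changes the number modestly, whereas these steps show that the whole ring contributes to inhibition, yet is not required for it, since compound 3 still gives 4.5 nM in this assay. Nothing available here explains how this group exerts its effect on the number.

The compounds shown leave open whether the gain comes from the ring's amine nitrogen or simply from having a ring of that size at this position, a question that a cyclohexyl group, with carbon in place of that nitrogen, could help to answer. On these data alone, it is also open how much of the gain a simple methyl or a short open chain ending in an amine on the same amide-type nitrogen would recover.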